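Furan in place of thiophene on an inactive nucleoside core

This account rests on a few compounds, and the source may have more. Where it says the series, first, only, none or still open, it means among the compounds named here.

Of the compounds shown here, two of this set have been measured in a functional assay on K562 cells (Homo sapiens), read by MTT assay, with a stated time of 72 h; on this read-out higher numbers stand for weaker inhibition and lower numbers for stronger inhibition. Compound 1, with structure `Nc1nc(N)c2c(-c3ccsc3)cn([C@@H]3O[C@H](CO)[C@@H](O)[C@H]3O)c2n1`, carries a thiophen-3-yl group on its core and, together with an amino group in place of the methyl, gives only the assay limit of > 20000 nM in this assay. Compound 2, with structure `Cc1nc(N)c2c(-c3cccs3)cn([C@@H]3O[C@H](CO)[C@@H](O)[C@H]3O)c2n1`, carries a thiophen-2-yl group and likewise reaches only the limit of > 20000 nM in this assay. Where compound 2 stands is therefore fixed only as a boundary: the limit of > 20000 nM in this assay, at which 2 of the 2 values shown sit, so no number separates the two measured compounds, and no step between them can be sized.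

The unmeasured compound 3, with structure `Cc1nc(N)c2c(-c3ccco3)cn([C@@H]3O[C@H](CO)[C@@H](O)[C@H]3O)c2n1`, differs from compound 2 by a single change: furan-2-yl in place of thiophen-2-yl on an aromatic carbon. Since both measured compounds sit at the same limit, there is no basis for expecting a step beyond the scatter, and the expected step from compound 2 to compound 3 is a step that the limit leaves unreadable from compound 2 to compound 3, most likely again reported only as a limit. Compound 3 is thus estimated at 25000 nM, with an expected range from 8000 nM to 80000 nM in this assay.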

Compound 3, half-maximal inhibitory concentration: > 20000 nM
Compound 3: no number, only a limit; the forecaster's own chance of this, stated with the estimate: 80%; the middle value is on the limit's open side.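

In this assay compound 3 gives > 20000 nM as a limit and not a number. Among the compounds shown here, no step from compound 2 to compound 3 can be read, since neither compound has a number: the limit of > 20000 nM in this assay, at which 3 of the 3 values shown sit. The compounds shown leave open how furan-2-yl and thiophen-2-yl compare, and whether any group on the shared core gives a measurable value.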